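Hydroxymethyl Replacing Isopropyl in an Acyltransferase Inhibitor Series

The compounds below may be only part of what the source reports. "The series", "measured", "known", "first", "only" and "open" are said of these compounds alone.

Three compounds have been measured in an assay on microsomes for inhibition of acyl-CoA:cholesterol acyltransferase (Oryctolagus cuniculus); on this read-out lower numbers stand for stronger inhibition and higher numbers for weaker inhibition:
Compound 1, `CC(C)c1ccc(C2(CNC(=O)Nc3c(C(C)C)cccc3C(C)C)CCCC2)cc1`, gives 48 nM.
Compound 2, `CC(C)c1cccc(C(C)C)c1NC(=O)NCC1(c2ccc(OCc3ccccc3)cc2)CCCC1`, gives 34 nM.
Compound 3, `CC(C)c1cccc(C(C)C)c1NC(=O)NCC1(c2cccc(CO)c2)CCCC1`, gives 15 nM.

Compound 1 stands highest of these three numbers. Compound 4, `CC(C)c1cccc(C(C)C)c1NC(=O)NCC1(c2ccc(CO)cc2)CCCC1`, is not yet measured; the change from compound 1 is hydroxymethyl in place of isopropyl on an aromatic carbon. Going by the values given here, two measured steps bear on it: a 1.4-fold lower number from compound 1 to compound 2 (0.15 log units; within the scatter) swapped the same isopropyl group on the same aromatic carbon and stayed within the scatter, while a 3.2-fold lower number from compound 1 to compound 3 (0.51 log units; beyond the scatter) introduced the same hydroxymethyl group and produced a modest lowering. A modest lowering is therefore expected, a 2.4-fold lower number from compound 1 to compound 4 (0.38 log units; beyond the scatter). Compound 4 is estimated at 20 nM, with a range from 8 nM to 50 nM.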

Compound 4, half-maximal inhibitory concentration: 26 nM
For compound 4 the middle estimate is 1.3-fold (0.11 log units) below the measured one; the range from low to high includes it.
By their numbers in this assay, from the lowest: compounds 3, 4, 2 and 1 (each within the scatter of the next, the first and the last beyond it).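

In this assay, hydroxymethyl in place of isopropyl gives a 1.8-fold lower number from compound 1 to compound 4 (0.27 log units; within the scatter), so adding a hydrogen-bond donor and acceptor here produces no change that can be told from the scatter. Replacing benzyloxy with hydroxymethyl gives a 1.3-fold lower number from compound 2 to compound 4 (0.12 log units; within the scatter), so isopropyl, benzyloxy and hydroxymethyl all read alike at this position. The 4-(hydroxymethyl)phenyl group in place of 3-(hydroxymethyl)phenyl gives a 1.7-fold higher number from compound 3 to compound 4 (0.24 log units; within the scatter), so moving the hydroxymethyl also shows no clear effect. Nothing available explains why these compounds read alike. Going by these compounds, whether an amine or a carboxylic acid would also be accepted at this position remains open.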